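The compounds below may be only part of what the source reports. "The series", "measured", "known", "first", "only" and "open" are said of these compounds alone.

Measured compounds, dose for half-maximal effect in a toxicity assay on the whole organism (strain Icem-CET (SPF Caw)) for cytotoxicity, with Mus musculus as the target; a lower number here means that less compound is needed, a higher number that more compound is needed for the effect:

compound 1, `C/C(C(=O)NC1CC1)=C(/C)c1ccc(Br)cc1`: 130 mg/kg
compound 2, `C/C(C(=O)NC1CC1)=C(/C)c1ccc(Cl)cc1`: 150 mg/kg
compound 3, `C/C(C(=O)NC1CC1)=C(/C)c1ccc(C)cc1`: 150 mg/kg

Compound 2 stands level with compound 3 at the digits given, and the two of them are together the highest of the three numbers; compound 1 lies closest below, within the scatter.

Compound 4, `C#CCNC(=O)/C(C)=C(\C)c1ccc(Cl)cc1`, has not been measured in this assay. It differs from compound 2 in one place: propargyl in place of cyclopropyl on an amide-type nitrogen.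

The three measured steps all concern the group on the aromatic carbon: a 1.2-fold higher number from compound 1 to compound 2 (0.06 log units; within the scatter), a 1.2-fold higher number from compound 1 to compound 3 (0.06 log units; within the scatter) and no change at the digits printed from compound 2 to compound 3 (within the scatter). Among the measured compounds shown here, none of them touches the amide-type nitrogen, so no step bears directly on the change from compound 2 to compound 4. What the series does show is that every change tried so far has left this assay unmoved beyond the scatter. On that basis no step beyond the scatter is expected for compound 4 either, with the direction undetermined; the estimated step is no change at the digits printed from compound 2 to compound 4 (within the scatter). Compound 4 is therefore expected to give about 150 mg/kg, with a range from 75 mg/kg to 300 mg/kg.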

Compound 4, dose for half-maximal effect: 200 mg/kg
The estimate for compound 4 lay 1.3-fold (0.12 log units) below the measured number; the range from low to high includes it.
By their numbers in this assay, from the lowest: compounds 1, 2, 3 and 4 (each within the scatter of the next).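

Among the compounds shown, only this pair differs on the amide-type nitrogen, and in this assay propargyl in place of cyclopropyl gives a 1.3-fold higher number from compound 2 to compound 4 (0.12 log units; within the scatter) in the series. This position therefore joins the aromatic carbon as a place where the changes shown stay within the scatter. That holds even though an open chain with a triple bond replaces a three-membered ring of the same heavy-atom count. No supporting measurement is available that would explain this result.

Still open, on these data alone, is whether a longer chain, an amine or a carboxylic acid on the amide-type nitrogen would shift the number in this assay beyond the scatter. Also open, as far as these compounds go, is whether propargyl in place of cyclopropyl reads the same with bromo or methyl on the aromatic carbon.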